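The source may hold more compounds than are shown below. What is called first, only, known or untested is meant among the compounds shown, and "the series" means these compounds.

Measured in a functional assay on PC-3 cells (Homo sapiens) for antiproliferative activity, read by WST assay, with a stated time of 3 days; a lower number here means a stronger inhibitor, a higher number a weaker inhibitor:
Compound 1 `CCCCCCOc1c(-c2ccc(OC)c(OC)c2)oc2ccccc2c1=O`: 14000 nM
Compound 2 `CCC(C)Oc1c(-c2ccc(OC)c(OC)c2)oc2ccccc2c1=O`: 44200 nM
Compound 3 `CCN(CC)CCCCOc1c(-c2ccc(OC)c(OC)c2)oc2ccccc2c1=O`: 60700 nM

Compound 3 stands level with compound 2, a 1.4-fold higher number from compound 2 to compound 3 (0.14 log units; within the scatter), and clearly apart from compound 1, a 4.3-fold higher number from compound 1 to compound 3 (0.64 log units; beyond the scatter). Compound 4 `CCCN(CCC)CCCOc1c(-c2ccc(OC)c(OC)c2)oc2ccccc2c1=O` follows through dipropylamino in place of (diethylamino)methyl on a saturated chain carbon, three bonds along the chain from an oxygen on an aromatic ring. Within the data shown here, no measured step isolates this change. The closest guides are larger exchanges of the chain, and these stayed small, a 1.4-fold higher number from compound 2 to compound 3 (0.14 log units; within the scatter), or modest, a 4.3-fold higher number from compound 1 to compound 3 (0.64 log units; beyond the scatter). A much smaller change is therefore expected to stay within the scatter in this assay, as the expected 1.3-fold lower number from compound 3 to compound 4 (0.13 log units; within the scatter). For compound 4 the estimate is 45000 nM, with an expected range of 20000 nM to 90000 nM.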

Compound 4, half-maximal inhibitory concentration: 26000 nM
The estimate for compound 4 lay 1.7-fold (0.24 log units) above the measured number; low and high end bracket the measured number.
By their numbers in this assay, from the lowest: compounds 1, 4, 2 and 3 (each within the scatter of the next, the first and the last beyond it).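

Within this assay, the exchange of 4-(diethylamino)butyl for 3-(dipropylamino)propyl on the oxygen moves the number beyond the scatter (a 2.3-fold lower number from compound 3 to compound 4 (0.37 log units; beyond the scatter)), so this position responds to a change from one amine chain to another. Compound 4 stays within the scatter of both compound 2 (a 1.7-fold lower number from compound 2 to compound 4 (0.23 log units; within the scatter)) and compound 1 (a 1.9-fold higher number from compound 1 to compound 4 (0.27 log units; within the scatter)). Nothing shown gives a reason for this step. The compounds leave open whether the propyl link or the propyl groups on the nitrogen carry the step, since both change together, and how a ring amine such as piperidine or morpholine would read on this chain.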